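The source may report more compounds than this note shows. Statements on the series, on what has been measured and on what is new or still open speak of the compounds shown alone.

Measured compounds:
compound 1, `CCOC(=O)[C@@H]1CCCN(S(=N)(=O)c2ccc(S(=O)(=O)N(CC)CC)cc2)C1`: 13300 nM
compound 2, `CCN(CC)S(=O)(=O)c1ccc(S(=O)(=O)N2CCC[C@@H](C(=O)N[C@@H]3CCN(C(=O)OC(C)(C)C)C3)C2)cc1`: 400 nM
compound 3, `CCCN(CCC)S(=O)(=O)c1ccc(S(=O)(=O)N2CCC[C@@H](C(=O)OCC)C2)cc1`: 2500 nM

In a functional assay on BXPC-3 cells (Homo sapiens) for inhibition, read by MTT assay, with a stated time of 7 days (a higher number here means a weaker inhibitor, a lower number a stronger inhibitor), compound 2 stands lowest of the three numbers; compound 3 lies higher by a gap beyond the scatter, and compound 1 lies higher still. Compound 4, `CCN(CC)S(=O)(=O)c1ccc(S(=O)(=O)N2CCC[C@@H](C(=O)NC3CN(C(=O)OC(C)(C)C)C3)C2)cc1`, has not been measured. It differs from compound 2 by 1-(tert-butoxycarbonyl)azetidin-3-yl in place of 1-(tert-butoxycarbonyl)pyrrolidin-3-yl on an amide-type nitrogen. Within the data shown here, no measured pair shows what such a ring contraction does in this assay. A shift of one ring member in a carbamate-capped ring on the amide nitrogen is expected to move the number little, with no step beyond the scatter, and a slight loss is held more likely than a gain. Compound 4 is therefore estimated at 600 nM, in a range from 200 nM to 2000 nM, which corresponds to an expected step of a 1.5-fold higher number from compound 2 to compound 4 (0.18 log units; within the scatter).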

Compound 4, half-maximal inhibitory concentration: 1800 nM
Compound 4: the middle estimate sits 3.0-fold (0.48 log units) below what was measured; the measured number falls inside the stated range.
By their numbers in this assay, from the lowest: compound 2; then compounds 4 and 3 (each within the scatter of the next); then compound 1.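

In this assay, among these compounds, a 4.5-fold higher number from compound 2 to compound 4 (0.65 log units; beyond the scatter) gives the first reading at this position: on the amide-type nitrogen, 1-(tert-butoxycarbonyl)azetidin-3-yl in place of 1-(tert-butoxycarbonyl)pyrrolidin-3-yl weakens inhibition, so this one-member ring contraction is not neutral. Among the compounds shown here, no earlier pair differed in one place, so the size of this change could not be read before. Nothing at hand accounts for the loss. The compounds shown leave open how a 1-(tert-butoxycarbonyl)piperidin-4-yl group would compare. They also leave open what the free pyrrolidine amine, without its tert-butoxycarbonyl group, would do.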